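Working notes: benzyl to 1-phenylethyl, compound 3 to compound 4

The compounds below may be only part of what the source reports. "The series", "measured", "known", "first", "only" and "open" are said of these compounds alone.

Measured so far, all in a functional assay on HL-60 cells (Homo sapiens) for cytotoxicity, read by MTT assay, with a stated time of 72 h; on this read-out higher numbers stand for weaker inhibition and lower numbers for stronger inhibition:
compound 1 `O=C1/C(=C\c2ccccn2)c2ccccc2N1Cc1ccccc1`: compound 1 gives 3600 nM
compound 2 `CC(c1ccccc1)N1C(=O)/C(=C\c2cccnc2)c2ccccc21`: compound 2 gives 3300 nM
compound 3 `O=C1/C(=C\c2ccc3ccccc3n2)c2ccccc2N1Cc1ccccc1`: compound 3 gives 2800 nM

Three compounds share the core and differ in the group on the ring nitrogen and in the aryl part of the exocyclic double bond. Compound 3 has the lowest of the three numbers in this assay, but its gaps to compound 2 and to compound 1 both lie within the scatter, so no order among the three can be read from these numbers. Going by the values given here, compound 1 and compound 2 differ in two places at once, so their two values are reported side by side only and no single step is known.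

The next compound, compound 4 `CC(c1ccccc1)N1C(=O)/C(=C\c2ccc3ccccc3n2)c2ccccc21`, keeps the aryl part of compound 3 and changes only the group on the ring nitrogen: methyl in place of hydrogen on a saturated chain carbon bound to an amide-type nitrogen in a ring and an aromatic carbon. Compound 1 and compound 2 carry the two variants of this same group, and their values in this assay sit close together, though the aryl part also differs between them. Among the compounds with values here, no step for this change alone has been measured.

The expectation is a step of no size beyond the scatter in this assay, i.e. no change at the digits printed from compound 3 to compound 4 (within the scatter) in either direction is not expected to exceed the usual spread. Compound 4 is therefore estimated at 2800 nM in this assay, with the range from 1200 nM to 6500 nM.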

Compound 4, half-maximal inhibitory concentration: 3400 nM
Estimate against measurement, compound 4: 1.2-fold (0.08 log units) below; measured number inside the range.
By their numbers in this assay, from the lowest: compounds 3, 2, 4 and 1 (each within the scatter of the next).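

Going by these compounds alone, compound 3 and compound 4 give the first reading of benzyl to 1-phenylethyl with the aryl part held fixed, which compound 1 and compound 2 could not give since they differ in two places at once. In this assay the change reads as a 1.2-fold higher number from compound 3 to compound 4 (0.08 log units; within the scatter), so methyl in place of hydrogen on this saturated chain carbon produces no resolved shift in this pair, and that finding applies only to the aryl part shared by these two compounds. No supporting data are available to explain this outcome.

It remains open whether the same change would also stay within the scatter with the aryl part of compound 1 or of compound 2, as neither of those aryl parts is shown with both groups on the ring nitrogen. Also open is how this assay would read with an ethyl group, an amine or a carboxylic acid in place of the methyl on this carbon, since a methyl is the only group shown there.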